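Compound 3 to compound 4: losing the trifluoromethoxy group

The compounds below may be only part of what the source reports. "The series", "measured", "known", "first", "only" and "open" are said of these compounds alone.

compound 1 `COc1cc(-c2ncnn2-c2cccc(F)c2)cc(OC)c1OC`: > 10000 nM (a limit)
compound 2 `COc1cc(-c2ncnn2-c2ccc(F)cc2)cc(OC)c1OC`: > 10000 nM (a limit)
compound 3 `COc1cc(-n2ncnc2-c2ccc(OC(F)(F)F)cc2)cc(OC)c1OC`: > 10000 nM (a limit)
compound 4 `COc1cc(-n2ncnc2-c2ccccc2)cc(OC)c1OC`: not yet measured

In a functional assay on Jurkat cells (Homo sapiens) for antiproliferative activity, read by MTT assay, with a stated time of 72 h (a lower number here means a stronger inhibitor, a higher number a weaker inhibitor), compound 3 gives > 10000 nM, which is a limit and not a number. No readable value exists for compound 3, so it cannot be ranked against compound 1 or compound 2, which also stop at a limit. For the measured compounds named here, the whole series so far shows the same result: the limit of > 10000 nM in this assay, at which 3 of the 3 values shown sit.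

In compound 4, hydrogen takes the place of trifluoromethoxy on an aromatic carbon of a six-membered aromatic ring of carbon only, para to a large group: hydrogen in place of trifluoromethoxy on an aromatic carbon.

Going by the values given here, the one measured step, a step that the two limits leave unreadable from compound 1 to compound 2, concerns a different change and gives no size to carry over. No step beyond the scatter can therefore be predicted in either direction in this assay, and another limit is the likeliest outcome. The expected step is a step that the limit leaves unreadable from compound 3 to compound 4. The estimate for compound 4 is 12000 nM, with an expected range from 4000 nM to 30000 nM.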

Compound 4, half-maximal inhibitory concentration: > 10000 nM
Compound 4: no number, only a limit; the forecaster's own chance of this, stated with the estimate: 85%; the middle value does not contradict the limit.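

In this assay, for the compounds shown here, compound 4 gives > 10000 nM, a limit and not a number, so no step from compound 3 to compound 4 can be read. All compounds shown end at the same result: the limit of > 10000 nM in this assay, at which 4 of the 4 values shown sit.

The compounds shown leave open how these four rank against each other and which change to the shared core, if any, would give a readable value in this assay.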